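Changing One Side Group on a Shared Core

This account rests on a few compounds, and the source may have more. Where it says the series, first, only, none or still open, it means among the compounds named here.

The two measured compounds and their values:
compound 1, `NS(=O)(=O)c1ccc2nc(N3N=C(c4ccc(Br)cc4)CC3c3ccc(F)cc3)sc2c1`: 14%
compound 2, `NS(=O)(=O)c1ccc2nc(N3N=C(c4ccc(Br)cc4)CC3c3cccs3)sc2c1`: 14%

Both were tested in a functional assay on the whole organism (strain Wistar) for inhibition, with Rattus norvegicus as the target, read by paw edema, with stated times of 1 h and 5 h, at a dose of 20 mg/kg by the oral route; on this read-out higher numbers stand for more inhibition at the one dose given (going by the name of the read-out) and lower numbers for less inhibition. Compound 1 gives 14%, and compound 2 gives 14%. Going by the values given here, the single step between them, no change at the digits printed from compound 1 to compound 2 (within the scatter), shows that exchanging one aromatic group on the saturated ring carbon left the read-out where it was. Compound 2 therefore stands level with compound 1; neither number can be called higher or lower than the other.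

Compound 3, `Cc1ccc(C2CC(c3ccc(Br)cc3)=NN2c2nc3ccc(S(N)(=O)=O)cc3s2)cc1`, is the next variation on the same saturated ring carbon: 4-methylphenyl in place of thiophen-2-yl on a saturated ring carbon. Among the compounds with values here, the only measured step that bears on this change is no change at the digits printed from compound 1 to compound 2 (within the scatter), which was no change within the scatter, so a third aromatic group at the same place is expected to behave alike. The expected step of no change at the digits printed from compound 2 to compound 3 (within the scatter) is none beyond the scatter. Compound 3 is therefore estimated at 14%, within a range from 4% to 26%.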

Compound 3, a percentage reported as inhibition, in the whole organism at one dose (the size of the read-out at that dose, not a potency): 14%
The estimate for compound 3 equals the measured number at the digits printed; the range from low to high includes it.
By their numbers in this assay, from the lowest: compounds 1, 2 and 3 (each within the scatter of the next).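

In this assay, replacing the five-membered sulfur-containing ring of thiophen-2-yl with the six-membered all-carbon ring of 4-methylphenyl gives no change at the digits printed from compound 2 to compound 3 (within the scatter), so this position has now met a second exchange of ring type with no visible effect on the read-out. Compound 3 also adds something the first pair could not show: it keeps the phenyl ring of compound 1 and exchanges only the group on that ring, methyl in place of fluoro on an aromatic carbon, and this gives no change at the digits printed from compound 1 to compound 3 (within the scatter). Nothing available here explains why these changes leave the number in place.

From the compounds shown here alone, all three compounds carry an aromatic ring on this saturated ring carbon, so it remains open whether a group without one, such as an amine, a carboxylic acid or a longer chain, would shift the read-out. All three also keep the 4-bromophenyl group, so the compounds shown say nothing about what exchanging that group, for example for a pyridine ring, would do.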